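Fluoro to chloro on the pendant aryl: solubility notes

A few compounds are considered here, and "the series" means these few. Any claim that something is new, unique, unknown or untested is made for them only; others in the source may bear on it.

Of the compounds shown here, three have been measured in a physicochemical assay for solubility, read by HPLC, in phosphate buffer, measured as kinetic solubility, at pH 7.4; on this read-out higher numbers stand for higher solubility and lower numbers for lower solubility. Compound 1 `CCOC(=O)c1cc(-c2ccc(Cl)cc2)n(-c2ccc(S(N)(=O)=O)cc2)c1` gives 10800 nM, compound 2 `CCOC(=O)c1cc(-c2ccc(F)cc2)n(-c2ccc(S(N)(=O)=O)cc2)c1` gives 36400 nM, and compound 3 `CCC(=O)c1cc(-c2ccc(F)cc2)n(-c2ccc(S(N)(=O)=O)cc2)n1` gives 88900 nM, the highest of the three. Compound 2 and compound 3 have different cores; the difference between the two cores is not broken down here. Within the core of compound 2, the change chloro in place of fluoro on an aromatic carbon produced a 3.4-fold lower number from compound 2 to compound 1 (0.53 log units; beyond the scatter). Compound 4 `CCC(=O)c1cc(-c2ccc(Cl)cc2)n(-c2ccc(S(N)(=O)=O)cc2)n1`, not yet measured, carries the same change on the core of compound 3: chloro in place of fluoro on an aromatic carbon. In this assay, within the data shown here, compound 4 is expected to show a 3.4-fold lower number from compound 3 to compound 4 (0.53 log units; beyond the scatter), the expectation resting on the single earlier step of a 3.4-fold lower number from compound 2 to compound 1 (0.53 log units; beyond the scatter). Compound 4 is therefore estimated at 26000 nM, with a range from 12000 nM to 55000 nM.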

Compound 4, solubility: 37800 nM
For compound 4 the middle estimate is 1.5-fold (0.16 log units) below the measured one; the range from low to high includes it.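

In this assay, chloro in place of fluoro on an aromatic carbon gives (a 2.4-fold lower number from compound 3 to compound 4 (0.37 log units; beyond the scatter)) on one core and (a 3.4-fold lower number from compound 2 to compound 1 (0.53 log units; beyond the scatter)) on the other. The direction of the change therefore carries over between these two cores, but two pairs cannot show that it would hold on a further core or that its size is general. Nothing measured here explains either step.

Open, on these data alone, is how an amine or a methoxy group would compare with fluoro and chloro at the same place on the aromatic ring. Also open, as far as these compounds go, is whether the change behaves alike on a core carrying a carboxylic acid where compound 1 and compound 2 carry the ethyl ester.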